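A Piperazine Swapped for a Piperidine

The source may report more compounds than this note shows. Statements on the series, on what has been measured and on what is new or still open speak of the compounds shown alone.

Measured in a functional assay on NCI-H2228 cells (Homo sapiens) for inhibition, read by MTT assay, with a stated time of 72 h (on this read-out higher numbers stand for weaker inhibition and lower numbers for stronger inhibition), so far:
compound 1 `CCc1nc2c(C)cc(-c3ccc(CN4CCC(O)CC4)cc3)cn2c1NC(=O)OCc1cc(Cl)cc(Cl)c1` gives 7360 nM
compound 2 `CCc1nc2c(C)cc(-c3ccc(CN4CCC[C@H]4CO)cc3)cn2c1NC(=O)OCc1cc(Cl)cc(Cl)c1` gives "nd" (no result reported)
compound 3 `CCc1nc2c(C)cc(-c3ccc(CN4CCN(C)CC4)cc3)cn2c1NC(=O)OCc1cc(Cl)cc(Cl)c1` gives "nd" (no result reported)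

Compound 3 has no single number in this assay to stand on, and only compound 1 offers one. Compound 4 `CCc1nc2c(C)cc(-c3ccc(CN4CCC(C)CC4)cc3)cn2c1NC(=O)OCc1cc(Cl)cc(Cl)c1` carries 4-methylpiperidin-1-yl in place of 4-methylpiperazin-1-yl on a saturated chain carbon bound to an aromatic carbon. Among the compounds with values here, no measured step can size this change, so its direction stays open. Within the data shown here, the one guide is compound 1 at 7360 nM in this assay, and compound 4 is expected to differ from that value by no more than the scatter. For compound 4 the estimated value is 6000 nM, with an expected range from 2000 nM to 18000 nM.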

Compound 4, half-maximal inhibitory concentration: 5150 nM
Compound 4: middle estimate off by 1.2-fold (0.07 log units), on the high side; the measured number falls inside the stated range.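

In this assay, methyl in place of hydroxy on a saturated ring carbon gives a 1.4-fold lower number from compound 1 to compound 4 (0.16 log units; within the scatter) and so leaves the number within the scatter, which means a hydroxy on that ring carbon is not needed to reach a value of this size. The change from 4-methylpiperazin-1-yl to 4-methylpiperidin-1-yl itself cannot be read, as compound 3 has no single number. Nothing measured here explains the result. Still open, as far as these compounds go, is how an amine, a carboxylic acid or a longer chain on that ring carbon would read.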